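Chain shortening from compound 1 to compound 3

This account rests on a few compounds, and the source may have more. Where it says the series, first, only, none or still open, it means among the compounds named here.

Among the measured compounds shown here, compound 1 `COc1ccc(N(C)c2nc(C)nc3ccccc23)cc1OCCCCCC[Se]C#N` stands at the highest number of the two measured so far: in a functional assay on HCT-116 cells (Homo sapiens) for inhibition, read by MTT assay, with a stated time of 48 h (on this read-out lower numbers stand for stronger inhibition and higher numbers for weaker inhibition), compound 1 gives 6180 nM, whereas compound 2 `Cc1nc(N(C)c2ccc([Se]C#N)c(C)c2)c2ccccc2n1` gives 13 nM, a gap far beyond the usual scatter. For the measured compounds named here, the two share the same core but differ in several places at once, so no single step connects them and only their two values can be set side by side. Compound 3 `COc1ccc(N(C)c2nc(C)nc3ccccc23)cc1OCCCCC[Se]C#N` differs from compound 1 in one place only: a group of 3 heavy atoms (1 carbon, 1 nitrogen, 1 selenium; no ring) in place of a group of 4 heavy atoms (2 carbon, 1 nitrogen, 1 selenium; no ring), on a saturated chain carbon, five bonds along the chain from an oxygen on an aromatic ring. The same terminal group is kept and the saturated chain between it and the aromatic oxygen is simply shorter. Going by the values given here, no step of this kind has yet been measured, so the expected step from compound 1 to compound 3 in this assay is a 1.0-fold lower number from compound 1 to compound 3 (0.01 log units; within the scatter), which is taken as lying within the scatter. Compound 3 is therefore estimated at 6000 nM, with a range from 2500 nM to 15000 nM.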

Compound 3, half-maximal inhibitory concentration: 256 nM
Estimate against measurement, compound 3: 23-fold (1.37 log units) above; the measured number lies below the stated range.
By their numbers in this assay, from the lowest: compound 2; then compound 3; then compound 1.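

In this assay, shortening the saturated chain on the aromatic oxygen gives a 24-fold lower number from compound 1 to compound 3 (1.38 log units; beyond the scatter) with the shared core and the terminal group kept. Among the compounds shown here, this is the first single change that can be read, and it shows that the number at this position responds strongly to chain length alone, which the earlier pair, differing in several places at once, could not show. No measurement at hand bears on what lies behind this step.

With only one step at this position, the compounds shown do not tell whether a still shorter chain would lower the number further or raise it again. They also leave open how an amine or a carboxylic acid in place of the terminal group would read at the same chain length.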